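Replacing a Tetrazole with a Methylpyrazole: an Expected Recovery

The source may hold more compounds than are shown below. What is called first, only, known or untested is meant among the compounds shown, and "the series" means these compounds.

Of the compounds shown here, three with a shared core have been measured. Compound 1 `Cc1cc(C)c(NC(=O)N(Cc2cc(-c3ccccc3)on2)C2CCCCCC2)c(C)c1` gives 61 nM in an assay on microsomes from intestine for inhibition of acyl-CoA:cholesterol acyltransferase (Oryctolagus cuniculus) (on this read-out lower numbers stand for stronger inhibition and higher numbers for weaker inhibition), and compound 3 `Cc1cc(C)c(NC(=O)N(Cc2cccc(-c3cc[nH]n3)c2)C2CCCC2)c(C)c1` gives 22 nM in this assay. Compound 2 `Cc1cc(C)c(NC(=O)N(Cc2cccc(-c3nn[nH]n3)c2)C2CCCCCC2)c(C)c1` is reported only as an assay limit, > 1000 nM, and not as a number. Within the set it is the single value sitting at that limit (the limit of > 1000 nM in this assay, at which 1 of the 3 values shown sits).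

Compound 4 `Cc1cc(C)c(NC(=O)N(Cc2cccc(-c3ccn(C)n3)c2)C2CCCCCC2)c(C)c1` departs from compound 2 by 1-methyl-1H-pyrazol-3-yl in place of 2H-tetrazol-5-yl on an aromatic carbon. Among the measured compounds shown here, no measured pair connects these two compounds. Compound 3, which carries a pyrazole rather than a tetrazole and gives 22 nM, suggests that this change should run toward stronger inhibition, so the writer expects an at least 16-fold lower number from compound 2 to compound 4 (1.22 log units; beyond the scatter), clearly beyond the scatter. Compound 4 is estimated at 60 nM, with a range from 15 nM to 300 nM.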

Compound 4, half-maximal inhibitory concentration: 42 nM
Compound 4: the middle estimate sits 1.4-fold (0.15 log units) above what was measured; the range from low to high includes it.
By their numbers in this assay, from the lowest: compounds 3, 4 and 1 (each within the scatter of the next, the first and the last beyond it). At a limit, above all of these: compound 2.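

With the rest of the structure unchanged, this position on the aromatic ring carries 1-methyl-1H-pyrazol-3-yl in place of 2H-tetrazol-5-yl with an at least 23-fold lower number from compound 2 to compound 4 (1.37 log units; beyond the scatter) in this assay. Among the compounds shown here, this is the first direct link between two groups at this position, as the earlier compounds differed in more than one place. Compound 2 remains a limit and not a number, so the step has no upper end: the limit of > 1000 nM in this assay, at which 1 of the 4 values shown sits.

The compounds shown leave open what the methyl on the pyrazole contributes with this core. They also leave open how a carboxylic acid or an amine at this position would read.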